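The source may hold more compounds than are shown below. What is called first, only, known or untested is meant among the compounds shown, and "the series" means these compounds.

Measured so far:
- compound 1, `COc1ccc(C2Nc3ccc(O)cc3C(=O)N2Cc2ccccc2)cc1COc1ccc(NC(C)=O)cc1`: 330 nM
- compound 2, `COc1ccc(C2Nc3ccccc3C(=O)N2Cc2ccccc2)cc1COc1ccccc1`: 2570 nM

For the measured compounds named here, compound 2 stands highest of the two numbers so far; its nearest neighbour, compound 1, gives a number lower by a margin beyond the scatter in a functional assay on HEK-EM293 cells for agonist activity at Thyrotropin receptor (Homo sapiens), read by ELISA and cAMP accumulation, with a stated time of 1 h; on this read-out higher numbers stand for an effect only at larger amounts of compound and lower numbers for an effect already at smaller amounts. The two differ in more than one place, so no single step can be read from them.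

Compound 3, `COc1ccc(C2Nc3ccccc3C(=O)N2Cc2ccccc2)cc1CSc1ccc(NC(C)=O)cc1`, is not yet measured. Against compound 2 the change is (4-acetamidophenyl)sulfanyl in place of phenoxy on a saturated chain carbon bound to an aromatic carbon. The entering group carries the acetamido that is also present in compound 1, while the hydroxyl on the core of compound 1 is absent in both compound 2 and compound 3.

Expectation in this assay: compound 3 is expected to move toward a lower number than compound 2, with a 2.6-fold lower number from compound 2 to compound 3 (0.41 log units; beyond the scatter) as the estimated step, because compound 1 with an acetamido-bearing ring gives 330 nM; the sulfur in place of oxygen carries no precedent here, so the range stays wide. The estimate for compound 3 is 1000 nM, within 300 nM to 3500 nM.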

Compound 3, half-maximal effective concentration: 80 nM
For compound 3 the middle estimate is 13-fold (1.10 log units) above the measured one; measured number outside the range, below it.
By their numbers in this assay, from the lowest: compound 3; then compound 1; then compound 2.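

In this assay the place on a saturated chain carbon bound to an aromatic carbon proves highly responsive on the shared core: putting (4-acetamidophenyl)sulfanyl in place of phenoxy gives a 32-fold lower number from compound 2 to compound 3 (1.51 log units; beyond the scatter) as a single change. For the compounds shown here, this is the first step that can be read at one place, since compound 1 and compound 2 differ in more than one place and no single step can be taken from that pair. Nothing measured here accounts for the size of the step.

The change swaps the linking oxygen for sulfur and adds the acetamido at once, so the compounds shown leave open how much of the step belongs to each; a plain phenylsulfanyl group on the same core would separate the two. Also open, as far as these compounds go, is what the acetamido itself contributes at this place, which an amine or a carboxylic acid in its stead on the ring would begin to show, and whether the hydroxyl on the core of compound 1 adds anything to (4-acetamidophenyl)sulfanyl.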